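The source may hold more compounds than are shown below. What is called first, only, known or untested is meant among the compounds shown, and "the series" means these compounds.

Compound 3 `COc1cc(-c2nn(-c3cccc(NC(=O)c4ccc(Cl)c(C(F)(F)F)c4)c3)cc2-c2ccncc2)ccc1Cl` carries an amide whose carbonyl carbon bears a 4-chloro-3-(trifluoromethyl)phenyl group. In a functional assay on UO-31 cells (Homo sapiens) for inhibition, read by sulforhodamine B assay, with a stated time of 48 h (a lower number here means that less compound is tolerated, a higher number that more compound is tolerated), compound 3 reaches only a limit of the measurement, > 32500 nM, so no number is known for it. Its two relatives stand in the same situation. Compound 1 `COc1cc(-c2nn(-c3cccc(NC(=O)c4cccc(C(F)(F)F)c4)c3)cc2-c2ccncc2)ccc1Cl` gives in this assay a limit of > 50000 nM. Compound 2 `COc1cc(-c2nn(-c3cccc(NC(=O)Nc4cccc(C(F)(F)F)c4)c3)cc2-c2ccncc2)ccc1Cl` is the urea counterpart of the amide; in this assay compound 2 likewise gives a limit of > 50000 nM. All three compounds thus sit at a limit, and the limit of > 50000 nM in this assay, at which 2 of the 3 values shown sit, together with the limit of > 32500 nM in this assay, at which 1 of the 3 values shown sits, means that none of the steps between them can be sized.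

The change to compound 4 `COc1cc(-c2nn(-c3cccc(NC(=O)Nc4ccc(Cl)c(C(F)(F)F)c4)c3)cc2-c2ccncc2)ccc1Cl` is (4-chloro-3-(trifluoromethyl)phenyl)amino in place of 4-chloro-3-(trifluoromethyl)phenyl on a carbonyl carbon. The closest measured precedent is a step that the two limits leave unreadable from compound 1 to compound 2, the same swap of an aryl amide for an aryl urea with the 3-(trifluoromethyl)phenyl group; the other two steps, a step that the two limits leave unreadable from compound 1 to compound 3 and a step that the two limits leave unreadable from compound 2 to compound 3, are equally unreadable. Nothing among these values points to a step beyond the scatter in either direction, and a value at the limit again is the likeliest outcome. Compound 4 is therefore expected at 60000 nM, within 20000 nM to 200000 nM, so that the expected step is a step that the limit leaves unreadable from compound 3 to compound 4, with a real chance that only a limit is reported once more.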

Compound 4, concentration lethal to 50% of the cells: > 32500 nM
Compound 4 gave a limit, no number; the forecaster's own chance of this, stated with the estimate: 85%; the middle value lies beyond the limit too.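

In this assay compound 4 gives > 32500 nM, a limit and not a number. Its steps from compound 1, compound 2 and compound 3 cannot be read, because all these values are limits: the limit of > 32500 nM in this assay, at which 2 of the 4 values shown sit.

The compounds shown leave open whether the amide-to-urea swap or the added chloro changes the result in this assay at all.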